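A few compounds are considered here, and "the series" means these few. Any claim that something is new, unique, unknown or untested is made for them only; others in the source may bear on it.

Cytotoxicity notes on the sulfinyl and sulfonyl pair.

Compound 1 `N#Cc1c(N)cccc1[S+]([O-])c1ccccc1Br` gives in a functional assay on MT4 cells (Homo sapiens) for cytotoxicity (on this read-out higher numbers stand for weaker inhibition and lower numbers for stronger inhibition), a value of 168000 nM. Compound 2 `N#Cc1ccccc1[S+]([O-])c1cccc(N)c1C#N` returns only the limit of the assay, > 200000 nM. Compound 3 `N#Cc1c(N)cccc1S(=O)(=O)c1ccc(Br)cc1` likewise returns only the assay limit, > 200000 nM. The change from compound 1 to compound 2 is cyano in place of bromo on an aromatic carbon and produced an at least 1.1-fold higher number from compound 1 to compound 2 (0.07 log units; that floor lies within the scatter); the size of that step is capped by the limit of > 200000 nM in this assay, at which 2 of the 3 values shown sit.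

Compound 4 `N#Cc1ccc(S(=O)(=O)c2cccc(N)c2C#N)cc1`, yet to be measured, carries the same kind of change against compound 3: cyano in place of bromo on an aromatic carbon. The place differs from the earlier step, para to a large group here against ortho to a large group there. The difference between the core of compound 3 and the core of compound 1 is not broken down here.

For compound 4 the step from compound 3 is expected to be a step that the limit leaves unreadable from compound 3 to compound 4, resting on compound 3 sitting at > 200000 nM and on the earlier step of an at least 1.1-fold higher number from compound 1 to compound 2 (0.07 log units; that floor lies within the scatter) having moved toward the limit. The expected value for compound 4 is 250000 nM, estimated between 150000 nM and 500000 nM, most likely reported as a limit.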

Compound 4, half-maximal inhibitory concentration: > 200000 nM
Compound 4: a limit, no number; the forecaster's own chance of this, stated with the estimate: 85%; the middle value does not contradict the limit.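

Compound 3 and compound 4 both return only a limit in this assay, so the step between them, cyano in place of bromo on an aromatic carbon, cannot be read: the limit of > 200000 nM in this assay, at which 3 of the 4 values shown sit.

Still open, from the compounds shown here alone, is whether that change moves the number in this assay at either place, and how the core of compound 3 compares with the core of compound 1.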